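Swapping chloro for tert-butyl on the aromatic ring

This account rests on a few compounds, and the source may have more. Where it says the series, first, only, none or still open, it means among the compounds named here.

Within the data shown here, in a functional assay on A549 cells (Homo sapiens) for antiproliferative activity, read by MTT assay, with a stated time of 72 h (a higher number here means a weaker inhibitor, a lower number a stronger inhibitor), compound 1 (`NC1=NC2(CCOCC2)N(OCCCOc2ccc(Cl)cc2)C(N)=N1`) gives 360 nM and holds the lowest of the two numbers measured so far. Compound 2 (`NC1=NC2(CCOCC2)N(OCCCOc2ccc(Cl)c(Cl)c2)C(N)=N1`) gives 790 nM and carries one more chloro on the aromatic ring. Compound 3 (`CC(C)(C)c1ccc(OCCCON2C(N)=NC(N)=NC23CCOCC3)cc1`) has not been measured yet. Its difference from compound 1 is tert-butyl in place of chloro on an aromatic carbon and amounts to tert-butyl in place of chloro on an aromatic carbon, para to a large group. Among the measured compounds shown here, no measured step tests this swap directly. The only one that bears on it is a 2.2-fold higher number from compound 1 to compound 2 (0.34 log units; beyond the scatter) for chloro in place of hydrogen on an aromatic carbon, so a similarly modest move toward weaker inhibition is expected. The expected step is a 1.5-fold higher number from compound 1 to compound 3 (0.18 log units; within the scatter) in this assay and remains a loose estimate. For compound 3 the estimated value is 550 nM with an expected range from 180 nM to 1700 nM across repeat measurements.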

Compound 3, half-maximal inhibitory concentration: 500 nM
Estimate against measurement, compound 3: 1.1-fold (0.04 log units) above, within the range that was stated.
By their numbers in this assay, from the lowest: compounds 1, 3 and 2 (each within the scatter of the next, the first and the last beyond it).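

At the aromatic carbon para to a large group, tert-butyl with its 4 heavy atoms replaces chloro with its 1 heavy atom, and this assay shows a 1.4-fold higher number from compound 1 to compound 3 (0.14 log units; within the scatter), so the two compounds cannot be told apart. The earlier compounds shown here tested only the addition of a chloro to the ring, whereas this pair changes the group at this position itself and shows that a chlorine atom on this carbon is not needed for a value in this range. No measured evidence is available to explain this result.

Going by these compounds, whether this carbon would accept an amine or a carboxylic acid remains open, as both groups compared here have no hydrogen-bond donors or acceptors. The effect of plain hydrogen or a methoxy group at this position is also unknown.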